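The source may report more compounds than this note shows. Statements on the series, on what has been measured and on what is new or still open speak of the compounds shown alone.

Measured compounds:

Compound 1 `O=c1[nH]c2ccccc2cc1/C=N/c1ccc(O)cc1` — in a functional assay, read by spectrophotometry, with a stated time of 1 h (on this read-out lower numbers stand for stronger inhibition and higher numbers for weaker inhibition), compound 1 gives "not active" (no number reported).
Compound 2 `Cc1ccc2[nH]c(=O)c(/C=N/Nc3ccccc3)cc2c1` — in this assay compound 2 gives 1470000 nM.
Compound 3 `Cc1ccc2[nH]c(=O)c(/C=N/Nc3ccc([N+](=O)[O-])cc3)cc2c1` — in this assay compound 3 gives 350000 nM.

Compound 2 stands at the highest of the two numbers recorded in this assay. Its nearest neighbour is compound 3, reached by a 4.2-fold lower number from compound 2 to compound 3 (0.62 log units; beyond the scatter), a modest step obtained with nitro in place of hydrogen on an aromatic carbon; compound 1 has no number at all, only the finding that it is not active.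

Compound 4 `Cc1ccc2[nH]c(=O)c(/C=N/c3ccc(O)cc3)cc2c1` has not yet been measured in this assay. It differs from compound 2 by 4-hydroxyphenyl in place of anilino on a double-bonded nitrogen. Among the measured compounds shown here, no measured step covers this exchange directly. For the measured compounds named here, the only measured step, a 4.2-fold lower number from compound 2 to compound 3 (0.62 log units; beyond the scatter), alters a substituent on the anilino ring and does not speak to its replacement. What does bear on compound 4 is compound 1, which carries the same 4-hydroxyphenyl group on the same double-bonded nitrogen and differs from compound 4 only by a methyl on the shared core; compound 1 was found not active in this assay. Compound 4 is therefore expected to sit at a high number, and an outcome of no measurable activity would not surprise. Its estimated step from compound 2 is a 1.7-fold higher number from compound 2 to compound 4 (0.23 log units; within the scatter), within or near the scatter. Compound 4 is estimated at 2500000 nM, with a range from 600000 nM to 10000000 nM.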

Compound 4, half-maximal inhibitory concentration: "not active" (no number reported)
Nothing numeric was reported for compound 4, so the estimate cannot be set against anything.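

Among the compounds shown here, compound 4, like compound 1, returned no number, so no step linking compound 4 to compound 2 or compound 3 can be read. Nothing shown here accounts for this result. The compounds shown leave open whether the lack of activity in compound 1 and compound 4 goes with 4-hydroxyphenyl in place of anilino.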